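The source may hold more compounds than are shown below. What is called first, only, known or untested is meant among the compounds shown, and "the series" means these compounds.

Of the compounds shown here, two have numbers so far. Compound 1 `CNC(=O)c1cc(Oc2ccc(Nc3nccc(N4CCCC4)n3)cc2)ccn1` in a functional assay on A549 cells (Homo sapiens) for inhibition, read by MTT assay, with a stated time of 72 h, tested at 20 uM (a lower number here means less inhibition, a higher number more inhibition at the concentration tested (going by the name of the read-out)), gives 59.6%. Compound 2 `CCN(CC)c1ccc(C(=O)Nc2ccc(Oc3ncnc4ccsc34)cc2)cc1` carries a diethylamino group on a benzamide-type arm and in this assay gives 63.8%, the higher of the two numbers, with compound 1 the nearest; the gap of compound 2 to compound 1 lies within the scatter, so the two cannot be placed in any order.

Compound 3 `CN(C)c1ccc(C(=O)Nc2ccc(Oc3ncnc4ccsc34)cc2)cc1` has not been measured. It differs from compound 2 in one place: dimethylamino in place of diethylamino on an aromatic carbon. The diethylamino group of compound 2 gives way to a dimethylamino group on the aromatic carbon; everything else in the molecule stays as in compound 2.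

Within the data shown here, no step between two measured compounds of this kind is available, so the size of the effect is not known from the series itself. A change of this small size is expected to leave the number close to that of compound 2, and the step from compound 2 to compound 3 in this assay is estimated at a number 5.8 percentage points lower from compound 2 to compound 3 (within the scatter), not beyond the scatter in either direction. Compound 3 in this assay is therefore estimated at 58%, in the range 40% to 76%.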

Compound 3, a percentage reported as inhibition, at one concentration (the size of the read-out at that concentration, not a potency): 50.8%
Beside the measured number, compound 3's estimate is 7.2 percentage points above it; measured number inside the range.
By their numbers in this assay, from the lowest: compounds 3, 1 and 2 (each within the scatter of the next, the first and the last beyond it).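

In this assay, among these compounds, the exchange of diethylamino for dimethylamino, on an aromatic carbon para to a large group, gives a number 13 percentage points lower from compound 2 to compound 3 (beyond the scatter) and provides the first one-place comparison. The earlier compounds shown here could not show this, since they differ in more than one place and their numbers lie within the scatter of each other. The number at this position therefore responds to the size of the amino substituent alone, as the change removes carbon while the counts of hydrogen-bond donors and acceptors stay the same and the rest of the molecule is untouched, although this is a single pair and supports no wider trend. Nothing available bears on why the number falls with this change.

Among the compounds shown here, with only this pair, it remains open whether the number would keep rising with a longer chain such as dipropylamino, or would fall further with a primary amine in the same place. A ring amine such as piperidine at this position would show whether the number follows the size of the group or depends on the open chains themselves.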